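The compounds below may be only part of what the source reports. "The series", "measured", "known", "first", "only" and "open" are said of these compounds alone.

Compound 1 `CC1OC(OC2CCCCC2OCCCCC(C(=O)O)C(=O)O)C(O)C(O)C1O`: in a functional assay on HL-60 cells (Homo sapiens) for inhibition (a higher number here means a weaker inhibitor, a lower number a stronger inhibitor), compound 1 reaches only the assay limit > 5000000 nM.
Compound 2 `CC1OC(OC2CCCCC2OCCCCCCC(C(=O)O)C(=O)O)C(O)C(O)C1O`: in this assay compound 2 likewise reaches only the assay limit > 5000000 nM.

Compound 2 therefore stands at a limit rather than a number, and both values shown sit there (the limit of > 5000000 nM in this assay, at which 2 of the 2 values shown sit). Among the compounds with values here, the only measured step bearing on the next change is a step that the two limits leave unreadable from compound 1 to compound 2, whose size the two limits leave unreadable. Compound 3 `CC1OC(OC2CCCCC2OCCCCCCCC(C(=O)O)C(=O)O)C(O)C(O)C1O` differs from compound 2 by 2,2-dicarboxyethyl in place of dicarboxymethyl on a saturated chain carbon, six bonds along the chain from an oxygen on a saturated carbon. With no readable step to build on, no shift beyond the scatter can be foreseen. Compound 3 is expected at 5000000 nM, between 2000000 nM and 20000000 nM, most likely again only as a limit. The step of a number no higher from compound 2 to compound 3 (the limit leaves the size open) is thus expected to be none beyond the scatter.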

Compound 3, half-maximal inhibitory concentration: > 5000000 nM
Compound 3: no number, only a limit; the forecaster's own chance of this, stated with the estimate: 90%; the middle value lies on the limit itself.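

Compound 3 also gives only a limit, so the steps among compound 1, compound 2 and compound 3 cannot be read: the limit of > 5000000 nM in this assay, at which 3 of the 3 values shown sit.

The compounds shown leave open whether lengthening the chain changes inhibition at all in this assay.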